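The source may hold more compounds than are shown below. What is called first, only, known or untested is meant among the compounds shown, and "the series" means these compounds.

Compound 1 `CC(C)N(Cc1ccc(C(=O)NO)cc1)Cc1cc(F)c(F)c(F)c1F` and compound 2 `CC(C)CN(Cc1ccc(C(=O)NO)cc1)S(=O)(=O)c1cc(F)c(F)c(F)c1F` share a hydroxamic acid core. In an assay on Sf9 cells for inhibition of histone deacetylase 11 (Homo sapiens), read by fluorescence and mobility shift assay (a lower number here means a stronger inhibitor, a higher number a weaker inhibitor), compound 1 gives > 1000 nM, which is a limit of the assay and not a number. Compound 2 in this assay gives > 1000 nM, also only a limit. Going by the values given here, both measured values therefore sit at the limit of > 1000 nM in this assay, at which 2 of the 2 values shown sit, and no measured step exists. Compound 3 `COCCN(Cc1ccc(C(=O)NO)cc1)S(=O)(=O)c1cc(F)c(F)c(F)c1F` differs from compound 2 by methoxymethyl in place of isopropyl on a saturated chain carbon bound to a sulfonamide nitrogen. Among the compounds with values here, with no measured step to lean on, the expected change from compound 2 to compound 3 in this assay is a step that the limit leaves unreadable from compound 2 to compound 3, none beyond the scatter. Compound 3 is accordingly expected near 2500 nM, in the range 700 nM to 10000 nM, most likely reported again as a limit only.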

Compound 3, half-maximal inhibitory concentration: > 1000 nM
Compound 3 ended at the assay's limit (the forecaster's own chance of this, stated with the estimate: 75%); the middle value does not contradict the limit.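

Compound 2 and compound 3 both stand at a limit in this assay and not at a number, so no step between them can be read: the limit of > 1000 nM in this assay, at which 3 of the 3 values shown sit.
The compounds shown leave open what true potency lies behind that limit and whether any change on the shared core gives a measurable value.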